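Working notes: carbonyl substituent variation across four compounds

The compounds below may be only part of what the source reports. "The series", "measured", "known", "first", "only" and "open" are said of these compounds alone.

Measured so far in a functional assay on the whole organism (strain Wistar) for inhibition, with Rattus norvegicus as the target, read by paw edema, with stated times of 60 min and 24 h, at a dose of 100 mg/kg by the oral route; on this read-out lower numbers stand for less inhibition and higher numbers for more inhibition at the one dose given (going by the name of the read-out):
Compound 1 `COc1cc2c(cc1OC)C(CC(=O)O)CC2` gives 26.7%.
Compound 2 `CCCCNC(=O)CC1CCc2cc(OC)c(OC)cc21` gives 36.7%.
Compound 3 `COc1cc2c(cc1OC)C(CC(=O)NC(C)(C)C)CC2` gives 40%.

Compound 2 stands second highest of the three numbers. Its nearest neighbour is compound 3, with a number 3.3 percentage points higher from compound 2 to compound 3 (within the scatter), and its furthest is compound 1, with a number 10 percentage points higher from compound 1 to compound 2 (within the scatter); neither gap counts as a real difference. Going by the values given here, the only step beyond the scatter is a number 13.3 percentage points higher from compound 1 to compound 3 (beyond the scatter), a modest one.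

Compound 4 `COc1cc2c(cc1OC)C(CC(=O)N1CCNCC1)CC2` is not yet measured. It differs from compound 2 as follows: piperazin-1-yl in place of butylamino on a carbonyl carbon. The step that bears on it most directly is the exchange of one group on an amide-type nitrogen for another, a number 3.3 percentage points higher from compound 2 to compound 3 (within the scatter), which stayed within the scatter. The two steps from compound 1, replacing hydroxy on the carbonyl carbon with an amine, were a number 10 percentage points higher from compound 1 to compound 2 (within the scatter) and a number 13.3 percentage points higher from compound 1 to compound 3 (beyond the scatter), so the move from the acid to an amide itself adds little beyond scatter. Compound 4 keeps the carbonyl with a nitrogen on it and changes only what that nitrogen carries, so no step beyond the scatter is expected in this assay, in either direction.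

For compound 4 the expected value is therefore 37%, with a range from 22% to 52%, which means an expected step of a number 0.3 percentage points higher from compound 2 to compound 4 (within the scatter).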

Compound 4, a percentage reported as inhibition, in the whole organism at one dose (the size of the read-out at that dose, not a potency): 65%
Estimate against measurement, compound 4: 28 percentage points below; measured number above the stated range.
By their numbers in this assay, from the lowest: compounds 1, 2 and 3 (each within the scatter of the next, the first and the last beyond it); then compound 4.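

In this assay the group on the carbonyl carbon proves able to move the number well beyond the scatter: piperazin-1-yl in place of butylamino gives a number 28.3 percentage points higher from compound 2 to compound 4 (beyond the scatter) and piperazin-1-yl in place of (tert-butyl)amino gives a number 25 percentage points higher from compound 3 to compound 4 (beyond the scatter) while the exchange of the two open-chain groups gave only a number 3.3 percentage points higher from compound 2 to compound 3 (within the scatter) and so did not reveal this. Having an amide at this carbonyl carbon is therefore not enough on its own to reach this level, and the full step from the acid, a number 38.3 percentage points higher from compound 1 to compound 4 (beyond the scatter) and marked as large, sets compound 4 beyond the scatter of all three other compounds, as the highest of the four at this one dose. No measurement at hand bears on why the piperazin-1-yl group has this effect.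

This change brings in a six-membered ring and an added nitrogen together, so the compounds shown cannot separate the contribution of the ring from that of the nitrogen; piperidin-1-yl, morpholin-4-yl or 4-methylpiperazin-1-yl on the same carbonyl carbon would address that. With a single dose, the compounds shown also leave open how the four would compare across a range of doses.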